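Indazolyl sulfonamide as a replacement for methoxyphenyl

The source may hold more compounds than are shown below. What is called first, only, known or untested is meant among the compounds shown, and "the series" means these compounds.

The series rests on a shared core, shown by compound 1 `CCN(Cc1ccccc1)C(=O)C1CCN(S(=O)(=O)c2cccc(OC)c2)CC1`, in which a methoxyphenyl sulfonyl group sits on the piperidine nitrogen. In a functional assay on CHO cells for positive allosteric modulation of muscarinic acetylcholine receptor M5 (Homo sapiens), read by calcium flux (on this read-out lower numbers stand for smaller maximal responses and higher numbers for larger maximal responses), compound 1 gives 77%. Within the data shown here, compound 2 `CCN(Cc1ccccc1)C(=O)C1CCN(S(=O)(=O)c2ccccc2OC)CC1` carries the same groups with the methoxy substituent in another arrangement; in this assay compound 2 is "not determined" (no result reported), so no single number stands for it, and no step between compound 2 and compound 1 can be given.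

Compound 3 `CCN(Cc1ccccc1)C(=O)C1CCN(S(=O)(=O)c2ccc3[nH]ncc3c2)CC1` is not yet measured. It differs from compound 2 in one place: 1H-indazol-5-yl in place of 2-methoxyphenyl on a sulfonyl sulfur. Among the measured compounds shown here, with no step between measured compounds to lean on, the direction of any change in this assay is open, and a step of moderate size in either direction, or none beyond the usual scatter, is expected. Compound 3 is estimated to reach 70%, with a range from 40% to 100%.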

Compound 3, largest response reached (reported as percent of maximum), in percent of the reference or control that the assay uses: 86%
Beside the measured number, compound 3's estimate is 16 percentage points below it; the measured number falls inside the stated range.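

In this assay, a number 9 percentage points higher from compound 1 to compound 3 (within the scatter) shows that a bicyclic 1H-indazol-5-yl group can take the place of 3-methoxyphenyl on the sulfonyl sulfur without leaving the range of the reference compound. The methoxy group is therefore not required at this position for a large maximal response, and the hydrogen-bond donor that enters with the 1H-indazol-5-yl is compatible with it. The step from compound 2 to compound 3 cannot be read, and nothing shown gives a reason for the result.

The compounds shown leave open whether that donor contributes at all, which a 1-methyl-1H-indazol-5-yl group on the sulfonyl sulfur would address. They also leave open how a 3-aminophenyl group would behave there, and whether the result holds with the rest of the shared core changed.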